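Swapping chloro for methoxy on an aryl ether of a cytotoxicity series

A few compounds are considered here, and "the series" means these few. Any claim that something is new, unique, unknown or untested is made for them only; others in the source may bear on it.

Measured so far:
- compound 1, `COc1ccc(Oc2ccc3c(NCCCNCc4cc(F)ccc4OC)ccnc3c2)cc1`: 7000 nM
- compound 2, `COc1cccc(CNCCCNc2ccnc3cc(Oc4ccc(Cl)cc4)ccc23)c1O`: 5700 nM
- compound 3, `CC(C)CCc1ccc2c(NCCCNCc3ccco3)ccnc2c1`: 11200 nM

All three compounds were tested in an ADME assay on HepG2 cells (Homo sapiens) for cytotoxicity, read by luminescence, CellTiter-Glo and ATP content, with a stated time of 72 h; on this read-out lower numbers stand for an effect already at smaller amounts and higher numbers for an effect only at larger amounts of compound. Compound 1 gives 7000 nM, compound 2 gives 5700 nM, and compound 3 gives 11200 nM. Compound 2 has the smallest of the three numbers, yet its gap to compound 1 and its gap to compound 3 both lie within the usual scatter of repeated measurements, so no difference between any pair of these compounds can be claimed.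

Compound 4, `COc1ccc(Oc2ccc3c(NCCCNCc4cccc(OC)c4O)ccnc3c2)cc1`, has not yet been measured. It is compound 2 with one change: methoxy in place of chloro on an aromatic carbon. Compound 1 already carries the 4-methoxyphenoxy group that enters here, and its number in this assay sits close to that of compound 2, though compound 1 also differs elsewhere, so this is only a loose pointer. For the measured compounds named here, no pair of measured compounds differs in exactly this one place.

Going by the values given here, with no measured step to guide the size, the expectation for compound 4 is a value near that of compound 2, with the step of a 1.2-fold higher number from compound 2 to compound 4 (0.09 log units; within the scatter) expected to stay within the scatter. Compound 4 is estimated at 7000 nM, with a range from 3000 nM to 16000 nM.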

Compound 4, half-maximal effective concentration: 5500 nM
For compound 4 the middle estimate is 1.3-fold (0.10 log units) above the measured one; the measured number falls inside the stated range.
By their numbers in this assay, from the lowest: compounds 4, 2, 1 and 3 (each within the scatter of the next, the first and the last beyond it).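

In this assay, going from 4-chlorophenoxy to 4-methoxyphenoxy gives a 1.0-fold lower number from compound 2 to compound 4 (0.02 log units; within the scatter), so this aromatic carbon, para to a large group, now has a direct one-place comparison, and the two numbers cannot be told apart. On the other side of the molecule, 2-hydroxy-3-methoxyphenyl in place of 5-fluoro-2-methoxyphenyl on a saturated chain carbon bound to an amine nitrogen gives a 1.3-fold lower number from compound 1 to compound 4 (0.10 log units; within the scatter), which also cannot be distinguished from repeat-measurement noise, so neither of these two single changes registers in this read-out. Nothing available here offers an explanation for the absence of a visible difference in either comparison.

At the aromatic position, the compounds shown cover only chloro and methoxy, so it stays open whether an amine or a carboxylic acid in that place would move the number beyond the scatter. Going by these compounds, it also stays open whether these same two changes would look equally small in a different cell type or with a different read-out.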